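From an isoxazole amide to a thiazole amide

The source may hold more compounds than are shown below. What is called first, only, known or untested is meant among the compounds shown, and "the series" means these compounds.

Compound 1 `O=C(Cn1cc(-c2ccc([N+](=O)[O-])cc2)nn1)Nc1nccs1` gives 1040 nM in a functional assay on BMDM cells (Mus musculus, strain C57BL/6) for inhibition, with a stated time of 2 days; on this read-out lower numbers stand for stronger inhibition and higher numbers for weaker inhibition. Compound 2 `COc1ccc(-c2cn(CC(=O)Nc3cc(C)on3)nn2)cc1` reaches only the limit of this assay, at > 30000 nM. Compound 3 `C#Cc1ccc(-c2cn(CC(=O)Nc3cc(C)on3)nn2)cc1` likewise stays at the limit of this assay, with > 30000 nM. The step that the two limits leave unreadable from compound 2 to compound 3 is therefore not readable. Two of the values shown sit at the limit of > 30000 nM in this assay, at which 2 of the 3 values shown sit. Compound 3 thus stands at a limit, and one further value shown is also a limit. Compound 4 `C#Cc1ccc(-c2cn(CC(=O)Nc3nccs3)nn2)cc1` differs from compound 3 by 1,3-thiazol-2-yl in place of 5-methyl-1,2-oxazol-3-yl on an amide-type nitrogen. Among the measured compounds shown here, no measured step tests this change directly; compound 1, which carries the same 1,3-thiazol-2-yl group, gives a number in this assay where both 5-methyl-1,2-oxazol-3-yl compounds gave only limits. Compound 4 is therefore expected to come off the limit, with an estimated step of an at least 10-fold lower number from compound 3 to compound 4 (1.00 log units; beyond the scatter). Compound 4 is estimated at 3000 nM, between 700 nM and 15000 nM.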

Compound 4, half-maximal inhibitory concentration: > 30000 nM
Compound 4: no number, only a limit; the forecaster's own chance of this, stated with the estimate: 25%; middle value at least 10-fold (1.00 log units) away from the limit.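

Compound 4 stays at a limit in this assay, so 1,3-thiazol-2-yl on an amide-type nitrogen does not bring a number on its own. With that group kept, ethynyl in place of nitro on an aromatic carbon gives an at least 28-fold higher number from compound 1 to compound 4 (1.46 log units; beyond the scatter), so the number seen for compound 1 depends on more than this group. The step between the two limit compounds cannot be read, and the limit now covers most of the series: the limit of > 30000 nM in this assay, at which 3 of the 4 values shown sit.

On these data alone, what an amine or a carboxylic acid in place of nitro would give with 1,3-thiazol-2-yl kept remains open. So does the effect of 5-methyl-1,2-oxazol-3-yl when paired with nitro.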